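This account rests on a few compounds, and the source may have more. Where it says the series, first, only, none or still open, it means among the compounds named here.

Measured so far:
Compound 1 `COc1ccc(C(=O)/C=C/c2ccc(Br)cc2)c2c1C=CC(C)(C)O2`: in a functional assay on SK-OV-3 cells (Homo sapiens) for antiproliferative activity, read by MTT assay, with a stated time of 24 h (a higher number here means a weaker inhibitor, a lower number a stronger inhibitor), only a limit, > 10000 nM.
Compound 2 `COc1ccc(C(=O)/C=C/c2ccc(N(C)C)cc2)c2c1C=CC(C)(C)O2`: 2750 nM.

Compound 2 holds the only number shown in this assay; the other value is a limit. Among the compounds with values here, the one measured step, an at least 3.6-fold lower number from compound 1 to compound 2 (0.56 log units; beyond the scatter), starts at the limit (the limit of > 10000 nM in this assay, at which 1 of the 2 values shown sits), so its size is itself only a lower bound.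

Compound 3 `COc1ccc(C(=O)/C=C/c2ccc(-c3ccccc3)cc2)c2c1C=CC(C)(C)O2` differs from compound 2 by phenyl in place of dimethylamino on an aromatic carbon. The step from compound 1 to compound 2 changed this same position, and the dimethylamino it brought now leaves again; a modest loss, back toward the region of compound 1, is expected, a 2.2-fold higher number from compound 2 to compound 3 (0.34 log units; beyond the scatter). Compound 3 is estimated at 6000 nM, within 2000 nM to 20000 nM.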

Compound 3, half-maximal inhibitory concentration: > 10000 nM
Compound 3 was reported as a limit (the forecaster's own chance of this, stated with the estimate: 35%); middle value at least 1.6-fold (0.22 log units) away from the limit.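

Of the three groups shown at this position, on an aromatic carbon para to a large group, only dimethylamino gives a number in this assay: phenyl in place of dimethylamino gives an at least 3.6-fold higher number from compound 2 to compound 3 (0.56 log units; beyond the scatter). Compound 3 stands only as a limit, > 10000 nM. The step between compound 1 and compound 3 cannot be read, both ends being limits: the limit of > 10000 nM in this assay, at which 2 of the 3 values shown sit.

From the compounds shown here alone, whether the nitrogen of dimethylamino matters here stays open; a primary amine, a morpholine or a methoxy at this position would test that. Going by these compounds, how far compound 1 and compound 3 lie past the limit also stays open.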